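From heptyl to cyclopentyl: notes on the series

This account rests on a few compounds, and the source may have more. Where it says the series, first, only, none or still open, it means among the compounds named here.

Values in a functional assay, read by fluorescence and spectrophotometry, with a stated time of 1 h; on this read-out lower numbers stand for an effect already at smaller amounts and higher numbers for an effect only at larger amounts of compound:
- compound 1 `C=CCCCCCCS(=O)(=O)/C=C/c1ccc(O)c(O)c1`: 6400 nM
- compound 2 `O=S(=O)(/C=C/c1ccc(O)c(O)c1)CCCCCCCO`: 5900 nM
- compound 3 `CCCCCCCCS(=O)(=O)/C=C/c1ccc(O)c(O)c1`: 6400 nM

Compound 3 stands at 6400 nM, level with compound 1 and within the scatter of compound 2. The next structure is compound 4 `O=S(=O)(/C=C/c1ccc(O)c(O)c1)CC1CCCC1`, with cyclopentyl in place of heptyl on a saturated chain carbon bound to a sulfonyl sulfur.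

Within the data shown here, three measured steps bear on this change, though only indirectly. They are a 1.1-fold lower number from compound 1 to compound 2 (0.04 log units; within the scatter), no change at the digits printed from compound 1 to compound 3 (within the scatter) and a 1.1-fold higher number from compound 2 to compound 3 (0.04 log units; within the scatter). All three lie within the scatter in this assay, so the series has so far shown no response to a change in this chain. None of them replaces heptyl with a ring, and the data hold no direct measure of such a change.

On that limited evidence, no step beyond the scatter is expected, and a wide range is kept. The estimated step is a 1.0-fold higher number from compound 3 to compound 4 (0.01 log units; within the scatter). For compound 4 the expected value is 6500 nM, with an estimated range from 3000 nM to 14000 nM.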

Compound 4, half-maximal effective concentration: 9400 nM
Compound 4: the middle estimate sits 1.4-fold (0.16 log units) below what was measured, within the range that was stated.
By their numbers in this assay, from the lowest: compounds 2, 1, 3 and 4 (each within the scatter of the next).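

In this assay, the ring at this position gives a 1.5-fold higher number from compound 3 to compound 4 (0.17 log units; within the scatter), and the steps from the other two chains read a 1.6-fold higher number from compound 2 to compound 4 (0.20 log units; within the scatter) and a 1.5-fold higher number from compound 1 to compound 4 (0.17 log units; within the scatter). The earlier compounds shown here varied only open chains, whereas these steps show that a five-membered non-aromatic ring of carbon only, on a saturated chain carbon bound to a sulfonyl sulfur, also produces no step beyond the scatter. No supporting data are available to explain these steps.

Still open, from the compounds shown here alone, is whether an amine, a carboxylic acid, a longer chain or a cyclohexyl ring in this place would produce a step beyond the scatter. All four compounds share the same core, so the series also leaves open whether this flat response would hold with a different core.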